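This account rests on a few compounds, and the source may have more. Where it says the series, first, only, none or still open, it means among the compounds named here.

In a functional assay on MCF7 cells (Homo sapiens) for cytotoxicity, read by MTT assay, with a stated time of 72 h (a lower number here means that less compound is tolerated, a higher number that more compound is tolerated), compound 1 `CCCCC[Se]c1nc([Se]CCCCC)c2cccnc2n1` gives 94600 nM, and compound 3 `[SeH]c1nc([SeH])c2cccnc2n1` gives 82700 nM. For compound 2 `Nc1nc([SeH])nc2ncccc12` the result is only a limit, > 100000 nM. Compound 2 therefore stands at the limit of > 100000 nM in this assay, at which 1 of the 3 values shown sits. Among the compounds with values here, the one measured step that touches compound 2, one selenium atom in place of one nitrogen atom on an aromatic carbon, is an at least 1.2-fold lower number from compound 2 to compound 3 (0.08 log units; that floor lies within the scatter). Compound 4 `CCCCC[Se]c1nc(N)c2cccnc2n1` differs from compound 2 by pentyl in place of hydrogen on a selenium. Within the data shown here, no measured step covers that change; compound 1, which carries pentyl on both selenium atoms, and compound 3, which carries none, show values that sit close together. Compound 4 is therefore expected to stay near compound 2, a step of a number no higher from compound 2 to compound 4 (the limit leaves the size open). The estimate for compound 4 is 100000 nM, from 50000 nM to 200000 nM.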

Compound 4, concentration lethal to 50% of the cells: 85000 nM
Estimate against measurement, compound 4: 1.2-fold (0.07 log units) above; low and high end bracket the measured number.
By their numbers in this assay, from the lowest: compounds 3, 4 and 1 (each within the scatter of the next). At a limit, above all of these: compound 2.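

In this assay, pentyl in place of hydrogen on a selenium gives an at least 1.1-fold lower number from compound 2 to compound 4 (0.07 log units; that floor lies within the scatter), a floor whose true size cannot be read. Going by these compounds, compound 2 remains a limit, so the size of that step stays open: the limit of > 100000 nM in this assay, at which 1 of the 4 values shown sits. One nitrogen atom in place of a group of 6 heavy atoms on an aromatic carbon gives a 1.1-fold lower number from compound 1 to compound 4 (0.05 log units; within the scatter), so with pentyl on the other selenium, this exchange stays within the scatter.

On these data alone, it remains open whether a longer chain or a benzyl group in place of pentyl on the selenium would move the number beyond the scatter.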